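Replacing methyl with methoxy on the shared core

The compounds below may be only part of what the source reports. "The series", "measured", "known", "first", "only" and "open" are said of these compounds alone.

In a functional assay on NCI-H23 cells (Homo sapiens) for cytotoxicity, read by colorimetric assay (a higher number here means a weaker inhibitor, a lower number a stronger inhibitor), compound 3 `Cc1ccc2c(c1)/C(=C1/Nc3ccccc3/C1=N\O)C(=O)N2Cc1ccc(C(=O)NO)cc1` gives 10 nM, the lowest of the three measured numbers, against compound 1 `O=C(NO)c1ccc(CN2C(=O)/C(=C3\Nc4ccccc4\C3=N/O)c3cc(Cl)ccc32)cc1` at 50 nM and compound 2 `COc1ccc2c(c1)/C(=C1/Nc3ccccc3/C1=N\O)C(=O)N2Cc1ccc(/C=C/C(=O)NO)cc1` at 50 nM. Compound 4 `COc1ccc2c(c1)/C(=C1/Nc3ccccc3/C1=N\O)C(=O)N2Cc1ccc(C(=O)NO)cc1` is the next comparison, with methoxy in place of methyl on an aromatic carbon.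

Within the data shown here, one measured step bears directly on this position: a 5.0-fold lower number from compound 1 to compound 3 (0.70 log units; beyond the scatter), a modest change beyond the scatter, with methyl in place of chloro. Substitution here can therefore move the number, although that single step does not show how methoxy will behave. Among the measured compounds shown here, compound 2 also carries methoxy and gives 50 nM, but no single-place step connects it with the other compounds. For the measured compounds named here, with compound 3 at 10 nM, the low end of the series so far, a modest move towards a higher number is expected. The estimated step is a 2.5-fold higher number from compound 3 to compound 4 (0.40 log units; beyond the scatter). For compound 4 the expected value is 25 nM, with an estimated range from 8 nM to 70 nM.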

Compound 4, half-maximal inhibitory concentration: 90 nM
Compound 4: the middle estimate sits 3.6-fold (0.56 log units) below what was measured; the whole stated range lies below it.
By their numbers in this assay, from the lowest: compound 3; then compounds 1, 2 and 4 (each within the scatter of the next).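

In this assay, methyl stands apart at this position, on an aromatic carbon para to a fused ring: methoxy in place of methyl gives a 9.0-fold higher number from compound 3 to compound 4 (0.95 log units; beyond the scatter), whereas methoxy in place of chloro gives only a 1.8-fold higher number from compound 1 to compound 4 (0.26 log units; within the scatter), so methoxy and chloro are not separated here. With methoxy held fixed, hydroxycarbamoyl in place of 2-(hydroxycarbamoyl)ethenyl gives a 1.8-fold higher number from compound 2 to compound 4 (0.26 log units; within the scatter), so the two groups are not separated on this background. Nothing available explains why methyl stands apart from methoxy and chloro.

Open, from the compounds shown here alone, is whether the advantage is particular to methyl or also extends to other groups here, such as ethyl or an amine. Also open, going by these compounds, is whether 2-(hydroxycarbamoyl)ethenyl and hydroxycarbamoyl remain inseparable when methyl occupies this position.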